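Series notes: one trifluoromethyl group removed from compound 3

A few compounds are considered here, and "the series" means these few. Any claim that something is new, unique, unknown or untested is made for them only; others in the source may bear on it.

Measured so far in a functional assay on SNB-19 cells (Homo sapiens) for inhibition, read by sulforhodamine B assay, with a stated time of 48 h, tested at 10 uM; on this read-out lower numbers stand for a stronger effect and higher numbers for a weaker effect at the one concentration tested:
- compound 1, `O=C(Nc1cccc(-n2cc(-c3ccncc3)c(-c3cc(O)cc(Cl)c3)n2)c1)Nc1ccc(Cl)c(Cl)c1`, gives 30.8%
- compound 2, `COc1cc(Cl)cc(-c2nn(-c3cccc(NC(=O)Nc4ccc(Cl)c(C(F)(F)F)c4)c3)cc2-c2ccncc2)c1`, gives 28.1%
- compound 3, `COc1cc(Cl)cc(-c2nn(-c3cccc(NC(=O)Nc4cc(C(F)(F)F)cc(C(F)(F)F)c4)c3)cc2-c2ccncc2)c1`, gives 26.1%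

Compound 3 does not separate from the other two: its number sits within the usual scatter of both compound 2 and compound 1, so the three measured compounds read as one level of effect on this read-out, with no ranking among them.

Compound 4, `COc1cc(Cl)cc(-c2nn(-c3cccc(NC(=O)Nc4cccc(C(F)(F)F)c4)c3)cc2-c2ccncc2)c1`, is the next member to be measured. Relative to compound 3 the change is hydrogen in place of trifluoromethyl on an aromatic carbon. Going by the values given here, nothing in the measured set pairs two compounds that differ in a single place, so no measured step gives a direct guide for this change.

Given that compound 3, compound 2 and compound 1 all cluster together in this assay despite differing at the same part of the molecule, the expectation is a small step, if any, and none that should clearly exceed the scatter; if it moves, a slightly higher number, that is a weaker effect, seems the more likely direction. The step expected is a number 6.9 percentage points higher from compound 3 to compound 4 (within the scatter). Compound 4 is therefore estimated at 33%, with a range from 18% to 50%.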

Compound 4, a percentage reported as activity, at one concentration (the size of the read-out at that concentration, not a potency): 16.1%
Beside the measured number, compound 4's estimate is 16.9 percentage points above it; measured number below the stated range.
By their numbers in this assay, from the lowest: compounds 4, 3, 2 and 1 (each within the scatter of the next, the first and the last beyond it).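

In this assay, the series now has its first pairs that differ in one place, and hydrogen in place of chloro on an aromatic carbon gives a number 12 percentage points lower from compound 2 to compound 4 (beyond the scatter), a modest step and the first to clear the scatter. Hydrogen in place of trifluoromethyl on an aromatic carbon gives a number 10 percentage points lower from compound 3 to compound 4 (within the scatter), which points the same way but does not separate the two compounds, so across these two pairs the second substituent on this ring is not needed to keep the effect on this read-out, and in the pair with the chloro group its replacement by hydrogen gives the stronger effect. No measured property of these compounds bears on these steps, and the data give no explanation for them.

Going by these compounds, only hydrogen, chloro and trifluoromethyl appear at this aromatic carbon, so it remains open whether a different kind of group there, such as an amine or a carboxylic acid, would keep or lose the effect. The compounds shown also do not say whether the trifluoromethyl group that remains in compound 4 contributes anything, as no compound pairs it with hydrogen in a single change.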